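This account rests on a few compounds, and the source may have more. Where it says the series, first, only, none or still open, it means among the compounds named here.

In an assay on isolated protein for inhibition of Gonadotropin-releasing hormone receptor (Homo sapiens) (a lower number here means a stronger inhibitor, a higher number a weaker inhibitor), compound 1 `CCCCCn1c(SCc2cc([N+](=O)[O-])ccc2OC)nc2cc(NC(=O)NC(C)(C)C)ccc21` gives 210 nM. Going by the values given here, compound 2 `COc1ccc([N+](=O)[O-])cc1CSc1nc2cc(NC(=O)NC(C)(C)C)ccc2n1C(C)C` keeps the same core and gives 62 nM, the lowest of the two numbers so far, the only step measured being a 3.4-fold lower number from compound 1 to compound 2 (0.53 log units; beyond the scatter) with isopropyl in place of pentyl on an aromatic nitrogen. Compound 3 `COc1ccc([N+](=O)[O-])cc1CSc1nc2cc(NC(=O)NC3CC3)ccc2n1C(C)C` differs from compound 2 at another site: cyclopropyl in place of tert-butyl on an amide-type nitrogen. Among the compounds with values here, no measured step alters the group on the amide-type nitrogen, so the step from compound 1 to compound 2 does not bear on this change, and the data give no direct guide to its size or direction. With nothing to anchor it, the change from compound 2 to compound 3 is expected to give a 1.9-fold higher number from compound 2 to compound 3 (0.29 log units; within the scatter), a step that may well stay within the scatter. For compound 3 the expected value in this assay is 120 nM, within a range of 40 nM to 400 nM.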

Compound 3, half-maximal inhibitory concentration: 1900 nM
Estimate against measurement, compound 3: 16-fold (1.20 log units) below, outside the stated range (above it).
By their numbers in this assay, from the lowest: compound 2; then compound 1; then compound 3.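

In this assay the group on the amide-type nitrogen proves to be a sensitive point: cyclopropyl, with 3 heavy atoms, in place of tert-butyl, with 4, gives a 31-fold higher number from compound 2 to compound 3 (1.49 log units; beyond the scatter) and so turns a small change in the group into a large change in the number. Going by these compounds alone, this site thus responds more strongly than the aromatic nitrogen did in the only earlier step, a 3.4-fold lower number from compound 1 to compound 2 (0.53 log units; beyond the scatter), although the two steps were measured at different sites and on different partners. Nothing given here accounts for the size of the new step.

The compounds shown do not separate the ring from the lost carbon, and cyclobutyl or isopropyl on the amide-type nitrogen would be needed to tell these apart. From the compounds shown here alone, whether the same step would hold with pentyl on the aromatic nitrogen also remains open.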